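Swapping Furan for Thiophene on a Shared Core

The compounds below may be only part of what the source reports. "The series", "measured", "known", "first", "only" and "open" are said of these compounds alone.

Of the compounds shown here, three with a shared core have been tested in an assay on membranes from HeLa cells for displacement of a labelled ligand from adenosine receptor A3 (Homo sapiens), read by scintillation counting, with a stated time of 180 min, tested at 1 uM; a lower number here means less inhibition, a higher number more inhibition at the concentration tested (going by the name of the read-out). Compound 1 `CCCOC(=O)C1=C(C)NC(=O)NC1c1ccsc1` gives 6%. Compound 2 `CC(=O)C1=C(C)NC(=O)NC1c1ccsc1` gives 1%. Compound 3 `CC1=C(C(N)=O)C(c2ccoc2)NC(=O)N1` gives 2%. All three numbers lie within the usual scatter of one another, so compound 3 stands level with both compound 1 and compound 2. Going by the values given here, the only measured step, a number 5 percentage points lower from compound 1 to compound 2 (within the scatter), concerns a methyl in place of propoxy on a carbonyl carbon and does not touch the five-membered aromatic ring. Compound 4 `CC1=C(C(N)=O)C(c2ccsc2)NC(=O)N1` differs from compound 3 by thiophen-3-yl in place of furan-3-yl on a saturated ring carbon. Compound 1 and compound 2 already carry thiophen-3-yl and give small numbers. The step of a number 1 percentage points higher from compound 3 to compound 4 (within the scatter) is thus expected to stay within the scatter. Compound 4 is estimated at 3%, in the range -6% to 12%.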

Compound 4, a percentage reported as inhibition, at one concentration (the size of the read-out at that concentration, not a potency): 1%
Compound 4: the middle estimate sits 2 percentage points above what was measured, within the range that was stated.
By their numbers in this assay, from the lowest: compounds 2, 4, 3 and 1 (each within the scatter of the next).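

In this assay, going by these compounds alone, thiophen-3-yl in place of furan-3-yl on a saturated ring carbon gives a number 1 percentage points lower from compound 3 to compound 4 (within the scatter) and is the one direct reading of this swap. Amino in place of methyl on a carbonyl carbon gives no change at the digits printed from compound 2 to compound 4 (within the scatter) and amino in place of propoxy gives a number 5 percentage points lower from compound 1 to compound 4 (within the scatter) so neither change separates these compounds at this concentration. Nothing available here explains these results.

As far as these compounds go, all four numbers are small, so it stays open whether this position can affect the read-out at all. A phenyl group on the saturated ring carbon, or a carboxylic acid in place of the carbamoyl group, would be the next tests.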